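The source may hold more compounds than are shown below. What is called first, only, known or untested is meant among the compounds shown, and "the series" means these compounds.

Compound 1 `CC/C(=C(/c1ccc(/C=C/C(=O)O)cc1)c1ccc2c(cnn2C)c1)c1ccc(F)cc1Cl`: 81 nM
Compound 2 `CC/C(=C(/c1ccc(/C=C/C(=O)O)cc1)c1ccc2[nH]ncc2c1)c1ccccc1`: 7.2 nM

Both compounds were tested in a functional assay on MCF7 cells (Homo sapiens) for antiproliferative activity, read by CellTiter-Glo, with a stated time of 5 days; on this read-out lower numbers stand for stronger inhibition and higher numbers for weaker inhibition. Compound 2 has the lower number of the two, at 7.2 nM, which means the stronger inhibition. The gap to compound 1, which gives 81 nM, lies beyond the scatter of repeated measurements.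

The next compound to consider is compound 3 `CC/C(=C(/c1ccc(/C=C/C(=O)O)cc1)c1ccc2c(cnn2C)c1)c1ccccc1`. It differs from compound 2 by one change, methyl in place of hydrogen on an aromatic nitrogen, which turns 1H-indazol-5-yl into 1-methyl-1H-indazol-5-yl.

For the measured compounds named here, no measured pair shows this change on its own, so its size in this assay cannot be read directly from the data. Going by the values given here, the only guide is compound 1, which also carries the 1-methyl-1H-indazol-5-yl group and gives 81 nM. On that basis, weaker inhibition is expected, with a rise beyond the scatter, and the estimated move is an 8.3-fold higher number from compound 2 to compound 3 (0.92 log units; beyond the scatter). The expected value for compound 3 is 60 nM, with an estimated range of 18 nM to 200 nM.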

Compound 3, half-maximal inhibitory concentration: 300 nM
The estimate for compound 3 lay 5.0-fold (0.70 log units) below the measured number; measured number above the stated range.
By their numbers in this assay, from the lowest: compound 2; then compound 1; then compound 3.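

In this assay, the methyl on the aromatic nitrogen, which turns 1H-indazol-5-yl into 1-methyl-1H-indazol-5-yl, can now be read on its own with phenyl held constant: it gives a 42-fold higher number from compound 2 to compound 3 (1.62 log units; beyond the scatter), a large loss of inhibition that exceeds what compound 1 alone had suggested. The second step shows that the group on the double-bonded chain carbon also matters once this methyl is in place, since phenyl in place of 2-chloro-4-fluorophenyl gives a 3.7-fold higher number from compound 1 to compound 3 (0.57 log units; beyond the scatter), a modest but real move towards weaker inhibition. Nothing available explains why either change shifts the number as it does.

The compounds shown leave open whether the methyl step keeps its size when 2-chloro-4-fluorophenyl replaces phenyl, and whether 2-chlorophenyl or 4-fluorophenyl alone would account for the second step. They also leave open how a larger group on that aromatic nitrogen, such as ethyl or a 2-hydroxyethyl chain, would compare with methyl and with hydrogen.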